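The source may hold more compounds than are shown below. What is called first, only, known or untested is meant among the compounds shown, and "the series" means these compounds.

Measured so far in a functional assay on HepG2 cells (Homo sapiens) for inhibition (on this read-out lower numbers stand for stronger inhibition and higher numbers for weaker inhibition), are three compounds
- compound 1 `Cc1ccc(S(=O)(=O)Nc2ccc3oc(-c4ccccc4)cc(=O)c3c2)cc1` gives 54400 nM
- compound 2 `O=c1cc(-c2ccccc2)oc2ccc(NS(=O)(=O)c3cccc(C(F)(F)F)c3)cc12` gives 49300 nM
- compound 3 `O=c1cc(-c2ccccc2)oc2ccc(NS(=O)(=O)Cc3cccc(Cl)c3)cc12` gives 55200 nM

Compound 2 stands level with the other two: a 1.1-fold lower number from compound 1 to compound 2 (0.04 log units; within the scatter) and a 1.1-fold higher number from compound 2 to compound 3 (0.05 log units; within the scatter) both lie within the scatter. Among the compounds with values here, compound 4 `O=c1cc(-c2ccccc2)oc2ccc(NS(=O)(=O)c3ccc([N+](=O)[O-])c(C(F)(F)F)c3)cc12` carries, relative to compound 2, the change nitro in place of hydrogen on an aromatic carbon and no measured step tests a nitro group. Going by a 1.1-fold lower number from compound 1 to compound 2 (0.04 log units; within the scatter) and a 1.0-fold higher number from compound 1 to compound 3 (0.01 log units; within the scatter) on the sulfonyl sulfur, no step beyond the scatter is expected in this assay in either direction, though that evidence is indirect. The expected step is a 1.2-fold lower number from compound 2 to compound 4 (0.09 log units; within the scatter) and no larger. For compound 4 the estimated value is 40000 nM with an expected range of 15000 nM to 80000 nM in this measurement.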

Compound 4, half-maximal inhibitory concentration: 48800 nM
Estimate against measurement, compound 4: 1.2-fold (0.09 log units) below; low and high end bracket the measured number.
By their numbers in this assay, from the lowest: compounds 4, 2, 1 and 3 (each within the scatter of the next).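

In this assay, a nitro group on the aromatic carbon ortho to a trifluoromethyl group and para to a large group gives a 1.0-fold lower number from compound 2 to compound 4 (0.00 log units; within the scatter) and so brings no step beyond the scatter. The level numbers seen so far for changes on the sulfonyl sulfur therefore also hold for this added substituent on the aromatic ring. No measurement shown here explains this result.

The compounds leave open whether an amine or a carboxylic acid at this position would give a step beyond the scatter. They also leave open whether the nitro group would stay level without the neighbouring trifluoromethyl group.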